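Swapping an amide for an oxetane on the shared core

This account rests on a few compounds, and the source may have more. Where it says the series, first, only, none or still open, it means among the compounds named here.

Measured in a functional assay on NCI-H2228 cells (Homo sapiens) for inhibition, read by CellTiter-Glo, with a stated time of 96 h; a lower number here means a stronger inhibitor, a higher number a weaker inhibitor:
- compound 1 `Cc1cc(Nc2ncc(Cl)c(Nc3cn(C)nc3S(=O)(=O)C(C)C)n2)c(OC2CC2)cc1C1CCCN(C)C1` gives 32 nM
- compound 2 `CCNC(=O)c1cc(OC2CC2)c(Nc2ncc(Cl)c(Nc3cn(C)nc3S(=O)(=O)C(C)C)n2)cc1C` gives 82 nM

Going by the values given here, with only two values in hand, compound 2 has the higher number at 82 nM, which makes it the weaker inhibitor of the pair. The next compound, compound 3 `Cc1cc(Nc2ncc(Cl)c(Nc3cn(C)nc3S(=O)(=O)C(C)C)n2)c(OC2CC2)cc1C1COC1`, has not yet been measured. It keeps the shared core and changes one group: oxetan-3-yl in place of ethylcarbamoyl on an aromatic carbon. In words, oxetan-3-yl takes the place of ethylcarbamoyl on an aromatic carbon, ortho to a methyl group.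

Among the compounds with values here, one measured step bears on this place: a 2.6-fold higher number from compound 1 to compound 2 (0.41 log units; beyond the scatter), a modest change that arose when ethylcarbamoyl replaced 1-methylpiperidin-3-yl. Oxetan-3-yl appears in neither measured compound, so that step offers only a rough guide to size. In this assay, a smaller step towards a lower number is therefore expected, or none beyond the scatter. The expected step is a 1.4-fold lower number from compound 2 to compound 3 (0.14 log units; within the scatter). For compound 3 the estimated value is 60 nM, with an expected range from 20 nM to 180 nM.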

Compound 3, half-maximal inhibitory concentration: 44 nM
For compound 3 the middle estimate is 1.4-fold (0.13 log units) above the measured one; the range from low to high includes it.
By their numbers in this assay, from the lowest: compounds 1, 3 and 2 (each within the scatter of the next, the first and the last beyond it).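

In this assay, putting oxetan-3-yl in place of ethylcarbamoyl on this aromatic carbon, ortho to a methyl group, gives a 1.9-fold lower number from compound 2 to compound 3 (0.27 log units; within the scatter) and so cannot be told apart from no change, although the hydrogen-bond donor of ethylcarbamoyl is gone and the open chain has given way to a four-membered ring. Compared with the basic-free picture of the amide alone, the more telling reading is that oxetan-3-yl also cannot be separated from the group in compound 1: oxetan-3-yl in place of 1-methylpiperidin-3-yl gives a 1.4-fold higher number from compound 1 to compound 3 (0.14 log units; within the scatter) and thus sits within the scatter of both neighbours, even though those two neighbours differ from each other by more than the scatter. Nothing available here explains why these groups behave alike at this place.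

A carboxylic acid or a simple primary amine on this carbon could show whether the tolerance seen so far extends to very different groups. A larger ring such as morpholine would likewise test how much size this place accepts, and all of these readings rest on a single cell assay.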